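One aryl group exchanged on a shared core

A few compounds are considered here, and "the series" means these few. Any claim that something is new, unique, unknown or untested is made for them only; others in the source may bear on it.

In a functional assay on SK-N-SH cells (Homo sapiens) for cytotoxicity, read by MTT assay, with a stated time of 24 h (a higher number here means a weaker inhibitor, a lower number a stronger inhibitor), compound 1 `C/C(=N\NC(=O)/C(C#N)=C/c1ccc(O)cc1)c1c(O)c2ccc(O)cc2oc1=O` gives 8120 nM and compound 2 `COc1cc(/C=C(\C#N)C(=O)N/N=C(\C)c2c(O)c3ccc(O)cc3oc2=O)ccc1O` gives 14400 nM while compound 3 `COc1cc(/C=C(\C#N)C(=O)N/N=C(\C)c2c(O)c3ccc(O)cc3oc2=O)cc(OC)c1OC` gives 14600 nM on the same shared core. Compound 2 lies within the usual scatter of both compound 1 and compound 3, so no order can be read around it.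

Compound 4 `C/C(=N\NC(=O)/C(C#N)=C/c1ccc(N(C)C)cc1)c1c(O)c2ccc(O)cc2oc1=O` has not yet been measured. Relative to compound 2 it carries 4-(dimethylamino)phenyl in place of 4-hydroxy-3-methoxyphenyl on a double-bonded chain carbon bound to a double-bonded chain carbon and the rest of the structure stays the same.

Among the compounds with values here, the only measured step that changes a single place is a 1.8-fold higher number from compound 1 to compound 2 (0.25 log units; within the scatter) for methoxy in place of hydrogen on an aromatic carbon, and it lies within the scatter. Within the data shown here, no measured compound carries 4-(dimethylamino)phenyl, so this step is only an indirect guide and the exchange itself remains untested. Among the measured compounds shown here, with that small step from compound 1 as the sole evidence, no change beyond the scatter is expected in this assay for the new compound. The expected step is a 1.4-fold lower number from compound 2 to compound 4 (0.16 log units; within the scatter) and this estimate stays within the scatter. Compound 4 is estimated at 10000 nM with 4000 nM and 25000 nM as the expected ends of its range.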

Compound 4, half-maximal inhibitory concentration: 6090 nM
The estimate for compound 4 lay 1.6-fold (0.22 log units) above the measured number; the measured number falls inside the stated range.
By their numbers in this assay, from the lowest: compounds 4, 1, 2 and 3 (each within the scatter of the next, the first and the last beyond it).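

In this assay, within the data shown here, the exchange at this position gives a step beyond the scatter, which the only earlier single-place step did not: a 2.4-fold lower number from compound 2 to compound 4 (0.37 log units; beyond the scatter), a modest change, when 4-(dimethylamino)phenyl replaces 4-hydroxy-3-methoxyphenyl on a double-bonded chain carbon bound to a double-bonded chain carbon. Measured against the compound without the methoxy, the change does not stand out: dimethylamino in place of hydroxy on an aromatic carbon gives a 1.3-fold lower number from compound 1 to compound 4 (0.12 log units; within the scatter), which lies within the scatter, so compound 4 and compound 1 cannot be placed in an order. The step beyond the scatter therefore appears only when the exchange is counted from compound 2, and no measurement on these compounds explains it.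

The compounds shown leave open whether an amino group, a diethylamino group or a morpholine in place of dimethylamino on an aromatic carbon would give a similar number. They also leave open how a dimethylamino group would read with a methoxy group kept on the same aryl group, which would separate the two changes contained in the step from compound 2.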